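A side-group swap at the edge of measurement

A few compounds are considered here, and "the series" means these few. Any claim that something is new, unique, unknown or untested is made for them only; others in the source may bear on it.

In an ADME assay on HEK293 cells (Homo sapiens) for cytotoxicity, read by ATP content, with a stated time of 6 h (a lower number here means that less compound is tolerated, a higher number that more compound is tolerated), compound 3 (`CC(Nc1nc(N)nc2ccn(Cc3ccccn3)c12)c1ccccn1`) gives > 24000 nM as a limit and not a number. Compound 1 (`COCCCNc1nc(N)nc2ccn(Cc3ccccn3)c12`) gives > 24000 nM as a limit too. Compound 2 (`CCC(O)CNc1nc(N)nc2ccn(Cc3ccccn3)c12`) gives > 24000 nM as a limit too. All three values therefore sit at one mark (the limit of > 24000 nM in this assay, at which 3 of the 3 values shown sit). Compound 4 (`Nc1nc(NCc2ncco2)c2c(ccn2Cc2ccccn2)n1`) carries (1,3-oxazol-2-yl)methyl in place of 1-(pyridin-2-yl)ethyl on a nitrogen on an aromatic ring. The measured changes at that same place (a step that the two limits leave unreadable from compound 1 to compound 3; a step that the two limits leave unreadable from compound 2 to compound 3) have no readable size, so they offer no direction. What is expected is a step that the limit leaves unreadable from compound 3 to compound 4 with no shift beyond the scatter. For compound 4 the estimate is 30000 nM (expected range 18000 nM to 60000 nM). A limit is again the likeliest report.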

Compound 4, half-maximal cytotoxic concentration: > 24000 nM
Compound 4: only a limit was reported; the forecaster's own chance of this, stated with the estimate: 90%; the middle value does not contradict the limit.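

Compound 4 also gives only a limit in this assay, so its steps from compound 1, compound 2 and compound 3 cannot be read: the limit of > 24000 nM in this assay, at which 4 of the 4 values shown sit. The compounds shown leave open each compound's actual half-maximal cytotoxic concentration, and whether changing this side group shifts it at all.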